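The compounds below may be only part of what the source reports. "The series", "measured", "known", "first", "only" and "open" are said of these compounds alone.

Measured so far:
- compound 1 `CC(C)c1noc(N2CCC(Oc3cc(N4CCc5cc(C6CCCCC6=O)ccc54)ncn3)CC2)n1`: 141 mL.min-1.g-1
- compound 2 `CCc1cnc(N2CCC(C(C)COC(=O)N3CCc4cc(S(C)(=O)=O)cc(F)c43)CC2)nc1`: 365 mL.min-1.g-1
- compound 3 `CC(C)c1noc(N2CCC(Oc3cc(N4CCc5cc(N6CCCNS6(=O)=O)ccc54)ncn3)CC2)n1`: 21 mL.min-1.g-1

In an ADME assay on microsomes from liver (Rattus norvegicus) for metabolic stability, read by LC-MS, using NADPH, with a stated time of 30 min, tested at 1 uM (a higher number here means faster removal of the compound, a lower number slower removal), compound 1 gives 141 mL.min-1.g-1, the second highest of the three numbers; compound 2 shows a higher value and compound 3 a lower one. Compound 4 `CC(C)c1noc(N2CCC(Oc3cc(N4CCc5cc(N6CCCS6(=O)=O)ccc54)ncn3)CC2)n1` is not yet measured. It differs from compound 1 in one place: a group of 7 heavy atoms (3 carbon, 1 nitrogen, 2 oxygen, 1 sulfur; one five-membered non-aromatic ring with 2 hetero atoms) in place of a group of 7 heavy atoms (6 carbon, 1 oxygen; one six-membered non-aromatic ring of carbon only), on an aromatic carbon. Within the data shown here, the one measured step that bears on this is the related replacement of the same group by a cyclic sulfonamide, a 6.7-fold lower number from compound 1 to compound 3 (0.83 log units; beyond the scatter). The change into compound 4 is of the same kind, so a lower number is expected, a 3.5-fold lower number from compound 1 to compound 4 (0.55 log units; beyond the scatter), though perhaps not as far. Compound 4 is therefore estimated at 40 mL.min-1.g-1, within a range of 15 mL.min-1.g-1 to 110 mL.min-1.g-1.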

Compound 4, intrinsic clearance in microsomes: 1 mL.min-1.g-1
The estimate for compound 4 lay 40-fold (1.60 log units) above the measured number; the measured number lies below the stated range.
By their numbers in this assay, from the lowest: compound 4; then compound 3; then compound 1; then compound 2.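

In this assay the five-membered ring with two hetero atoms gives a 140-fold lower number from compound 1 to compound 4 (2.15 log units; beyond the scatter) and, against the six-membered sulfur ring, a 21-fold lower number from compound 3 to compound 4 (1.32 log units; beyond the scatter). At this aromatic carbon, then, two sulfur-bearing rings of similar size are far apart, so carrying sulfur in the ring does not alone set the number. Nothing available explains this gap.

The compounds shown leave open how an open-chain group, such as a morpholine-free dimethylamine, or a morpholine ring at this place would compare. They also leave open whether the same ring gives such a low number on a different core.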